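This account rests on a few compounds, and the source may have more. Where it says the series, first, only, none or still open, it means among the compounds named here.

Measured so far in a functional assay for inhibition of sodium/hydrogen exchanger (Oryctolagus cuniculus); a lower number here means a stronger inhibitor, a higher number a weaker inhibitor:
compound 1 `Cc1cc(-c2ccc(Cl)cc2)c(S(C)(=O)=O)cc1C(=O)N=C(N)N` gives 45 nM;
compound 2 `Cc1cc(SC(C)(C)C)c(S(C)(=O)=O)cc1C(=O)N=C(N)N` gives 22 nM;
compound 3 `Cc1cc(-n2ccnc2)c(S(C)(=O)=O)cc1C(=O)N=C(N)N` gives 23 nM.

Compound 3 stands second highest of these three numbers in this assay, close to compound 2 and separated from compound 1 by a 2.0-fold lower number from compound 1 to compound 3 (0.29 log units; within the scatter), a gap that stays within the scatter. The step under study leads to compound 4 `Cc1cc(Nc2cccc(Cl)c2)c(S(C)(=O)=O)cc1C(=O)N=C(N)N`: (3-chlorophenyl)amino in place of 1H-imidazol-1-yl on an aromatic carbon. Going by the values given here, none of the measured steps places an amino-linked group at this carbon, and all of them were small: a 2.0-fold lower number from compound 1 to compound 2 (0.31 log units; beyond the scatter), a 2.0-fold lower number from compound 1 to compound 3 (0.29 log units; within the scatter) and a 1.0-fold higher number from compound 2 to compound 3 (0.02 log units; within the scatter). The nearest guidance comes from compound 1, whose 4-chlorophenyl group shares the chlorine-substituted six-membered ring of carbon only with the (3-chlorophenyl)amino group entering here, and which gave the highest of the three numbers. A small shift toward the number of compound 1 is therefore expected, amounting to an expected step of a 1.7-fold higher number from compound 3 to compound 4 (0.24 log units; within the scatter), within the scatter. Compound 4 is estimated at 40 nM, with a range from 15 nM to 120 nM.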

Compound 4, half-maximal inhibitory concentration: 33 nM
For compound 4 the middle estimate is 1.2-fold (0.08 log units) above the measured one; low and high end bracket the measured number.
By their numbers in this assay, from the lowest: compounds 2, 3, 4 and 1 (each within the scatter of the next, the first and the last beyond it).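

At the carbon ortho to the methylsulfonyl group in this assay, (3-chlorophenyl)amino proves to be accepted on a par with each earlier group, the steps being a 1.4-fold higher number from compound 3 to compound 4 (0.16 log units; within the scatter) and a 1.5-fold higher number from compound 2 to compound 4 (0.18 log units; within the scatter) and a 1.4-fold lower number from compound 1 to compound 4 (0.13 log units; within the scatter) in turn. The hydrogen-bond donor that enters with this group, absent from 1H-imidazol-1-yl, thus comes with no step beyond the scatter, and only compounds 1 and 2 remain beyond the scatter of each other. Nothing measured here explains why this carbon accepts such different groups. As far as these compounds go, whether a plain amine or a carboxylic acid at this carbon would keep the number in the same span remains open. So does the effect of a methyl group on the linking nitrogen of compound 4, or of a longer chain in place of its chlorophenyl ring.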